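Removing the chloro from the chain-end phenyl of compound 1

The source may hold more compounds than are shown below. What is called first, only, known or untested is meant among the compounds shown, and "the series" means these compounds.

Compound 1 `CC1SC(c2cccc(C(=O)NCCCCc3ccc(Cl)cc3)c2)N(c2cccc(C3CC3)c2)C1=O` gives 932 nM in a functional assay on HOS-TE85 cells (Homo sapiens) for inhibition, read by CCK-8 assay, with a stated time of 72 h (a lower number here means a stronger inhibitor, a higher number a weaker inhibitor), the highest of the two numbers in hand. Compound 2 `C#Cc1cccc(N2C(=O)CSC2c2cccc(C(=O)NCCCCc3ccccc3)c2)c1` gives 149 nM in this assay. Compound 3 `CCN1C(=O)CSC1c1cccc(C(=O)NCCCCc2ccccc2)c1` reaches only the assay limit > 1000 nM. For the measured compounds named here, the one measured step, an at least 6.7-fold higher number from compound 2 to compound 3 (0.82 log units; beyond the scatter), concerns the amide-type nitrogen in the ring, not the chain end; its limit value is noted as the limit of > 1000 nM in this assay, at which 1 of the 3 values shown sits. Compound 4 `CC1SC(c2cccc(C(=O)NCCCCc3ccccc3)c2)N(c2cccc(C3CC3)c2)C1=O` differs from compound 1 by hydrogen in place of chloro on an aromatic carbon. Going by the values given here, no measured step touches this position, so no shift beyond the scatter is expected, and the estimated step of a 1.1-fold lower number from compound 1 to compound 4 (0.04 log units; within the scatter) is small. Compound 4 is therefore expected to give about 850 nM in this assay, within 350 nM to 2000 nM.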

Compound 4, half-maximal inhibitory concentration: 295 nM
Estimate against measurement, compound 4: 2.9-fold (0.46 log units) above, outside the stated range (below it).
By their numbers in this assay, from the lowest: compounds 2 and 4 (each within the scatter of the next); then compound 1. At a limit, above all of these: compound 3.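

In this assay, for the compounds shown here, the step of a 3.2-fold lower number from compound 1 to compound 4 (0.50 log units; beyond the scatter) shows that the chain end is not a silent place on the core of compound 1, a position that no earlier step had touched. At this position on that core, phenyl gives the lower number and 4-chlorophenyl the higher, though this rests on a single pair. Nothing measured here accounts for the step.

As far as these compounds go, whether the same step holds on the core of compound 2 remains open. So does how a methoxy, a fluoro or an amine at this place would compare with hydrogen and chloro.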